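This account rests on a few compounds, and the source may have more. Where it says the series, first, only, none or still open, it means among the compounds named here.

Compound 2 `CCCCCCCCS(=O)(=O)Nc1cc(-c2ccc(O)cc2)ccc1C(=O)O` gives 64800 nM in an assay on mitochondria (strain BALB/c) for inhibition of glycerol-3-phosphate acyltransferase 1, mitochondrial (Mus musculus), read by scintillation counting, with a stated time of 10 min (a higher number here means a weaker inhibitor, a lower number a stronger inhibitor), and stands at the top of the two numbers shown, though only by a margin that the step of a 1.0-fold higher number from compound 1 to compound 2 (0.01 log units; within the scatter) places within the scatter, compound 1 `CCCCCCCCS(=O)(=O)Nc1cc(-c2ccccc2O)ccc1C(=O)O` giving 63100 nM. Compound 3 `CCCCCCCCS(=O)(=O)Nc1cc(/C=C/c2ccccc2)ccc1C(=O)O` differs from compound 2 by 2-phenylethenyl in place of 4-hydroxyphenyl on an aromatic carbon. Among the measured compounds shown here, no measured step covers a change of this kind: the single step of a 1.0-fold higher number from compound 1 to compound 2 (0.01 log units; within the scatter) stayed within the scatter, so the data give no direction for this assay. The chemist therefore expects compound 3 to stay close to compound 2, with an estimated 50000 nM between 15000 nM and 150000 nM, a step of a 1.3-fold lower number from compound 2 to compound 3 (0.11 log units; within the scatter).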

Compound 3, half-maximal inhibitory concentration: 38000 nM
The estimate for compound 3 lay 1.3-fold (0.12 log units) above the measured number, and the stated range covers the measured number.
By their numbers in this assay, from the lowest: compounds 3, 1 and 2 (each within the scatter of the next).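

In this assay, 2-phenylethenyl takes the place of either hydroxyphenyl group with a 1.7-fold lower number from compound 2 to compound 3 (0.23 log units; within the scatter) and with a 1.7-fold lower number from compound 1 to compound 3 (0.22 log units; within the scatter). The earlier compounds shown here varied only where the hydroxy group stood on a directly attached ring, whereas compound 3 has no hydrogen-bond donor or acceptor in this group and has a double bond outside aromatic rings, and its number still stays within the scatter of both. Nothing on hand explains this result.

On these data alone, what an amine or a carboxylic acid at this position would give stays open, as does whether any group here can move the number beyond the scatter.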